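The source may hold more compounds than are shown below. What is called first, only, known or untested is meant among the compounds shown, and "the series" means these compounds.

Compound 1 `CC(C)(C)OC(=O)NCCNC(=O)CN1CN(c2ccccc2)C2(CCN(C(=O)c3ccc(C4CCCCC4)cc3)CC2)C1=O` gives 5500 nM in an assay on HEK293 cells for displacement of a labelled ligand from NPC1-like intracellular cholesterol transporter 1 (Homo sapiens); on this read-out lower numbers stand for stronger inhibition and higher numbers for weaker inhibition. Compound 2 `O=C(CN1CN(c2ccccc2)C2(CCN(C(=O)c3ccc(C4CCCCC4)cc3)CC2)C1=O)NCCCCO` gives 10300 nM in this assay. Among the measured compounds shown here, these are the only two numbers, and they sit side by side: the step of a 1.9-fold higher number from compound 1 to compound 2 (0.27 log units; within the scatter) stays within the scatter, so neither compound can be set apart from the other. Compound 3 `CS(=O)(=O)NCCCNC(=O)CN1CN(c2ccccc2)C2(CCN(C(=O)c3ccc(C4CCCCC4)cc3)CC2)C1=O` differs from compound 2 by methanesulfonamido in place of hydroxymethyl on a saturated chain carbon, three bonds along the chain from an amide-type nitrogen. For the measured compounds named here, the one step that bears on this, a 1.9-fold higher number from compound 1 to compound 2 (0.27 log units; within the scatter), also swapped one chain end for another and shifted the number only within the scatter, so a similarly small move is expected, a 1.2-fold lower number from compound 2 to compound 3 (0.08 log units; within the scatter). Compound 3 is therefore estimated at 8500 nM, between 3000 nM and 25000 nM.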

Compound 3, half-maximal inhibitory concentration: 3800 nM
Estimate against measurement, compound 3: 2.2-fold (0.35 log units) above; the range from low to high includes it.
By their numbers in this assay, from the lowest: compounds 3, 1 and 2 (each within the scatter of the next, the first and the last beyond it).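

Among the compounds shown here, replacing hydroxymethyl with methanesulfonamido gives the first step beyond the scatter at this chain end (a 2.7-fold lower number from compound 2 to compound 3 (0.43 log units; beyond the scatter)), so the group placed here can shift the number, though only modestly. Compared with the (tert-butoxycarbonyl)amino group, the step stays within the scatter (a 1.4-fold lower number from compound 1 to compound 3 (0.16 log units; within the scatter)), so these two chain ends cannot be told apart. No measurement shown here explains the shift. On these data alone, whether an amine or a carboxylic acid at the chain end would move the number further remains open, as does the effect of a longer chain carrying methanesulfonamido.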